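This account rests on a few compounds, and the source may have more. Where it says the series, first, only, none or still open, it means among the compounds named here.

Working notes on the series. The series is followed in a functional assay on the whole organism (Tail, strain ICR) with Mus musculus as the target, in the tail flick test, with a stated time of 90 min, at a dose of 25 umol/kg by the oral route; on this read-out lower numbers stand for a weaker effect and higher numbers for a stronger effect at the one dose given. Compound 1 `O=C(O)[C@@H]1CCCN1C(=O)CN(c1nc(Cl)nc2[nH]cnc12)C1CC1` gives 26% in this assay. Compound 2 `CC(C)[C@H](NC(=O)CN(c1nc(Cl)nc2[nH]cnc12)C1CC1)C(=O)OCc1ccccc1` gives 51.3% in this assay. Compound 3 `CC[C@H](C)[C@H](NC(=O)CN(c1ncnc2c1ncn2C1CCCCO1)C1CC1)C(=O)OCc1ccccc1` gives 22.6% in this assay; its number and that of compound 1 lie within the scatter of each other, while the number of compound 2 stands above it by a gap beyond the scatter. Among the measured compounds shown here, no pair of the three measured compounds differs in a single place, so no single structural change has a measured step attached to it.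

Compound 4 `CC(C)(C)OC(=O)NCCCC[C@H](NC(=O)CN(c1ncnc2c1ncn2C1CCCCO1)C1CC1)C(=O)OCc1ccccc1` is not yet measured. It differs from compound 3 in one place: 4-((tert-butoxycarbonyl)amino)butyl in place of sec-butyl on a saturated chain carbon bound to an amide-type nitrogen and a carbonyl carbon. For the measured compounds named here, no measured step of this kind exists, so the expectation rests on the spread of the three measured numbers alone. A step of no more than the scatter, in either direction, is expected from compound 3 to compound 4, that is a number 3.4 percentage points higher from compound 3 to compound 4 (within the scatter). In this assay compound 4 is therefore estimated at 26%, with a likely range from 10% to 45%.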

Compound 4, a percentage reported as activity, at one dose (the size of the read-out at that dose, not a potency): 32.9%
Compound 4: the middle estimate sits 6.9 percentage points below what was measured; measured number inside the range.
By their numbers in this assay, from the lowest: compounds 3, 1 and 4 (each within the scatter of the next, the first and the last beyond it); then compound 2.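

In this assay, among the compounds shown here, 4-((tert-butoxycarbonyl)amino)butyl in place of sec-butyl on a saturated chain carbon bound to an amide-type nitrogen and a carbonyl carbon gives a number 10.3 percentage points higher from compound 3 to compound 4 (beyond the scatter), the only single-place step measured. This position therefore tolerates a much larger chain, one carrying a hydrogen-bond donor and hydrogen-bond acceptors where sec-butyl has none, with no loss of effect at the one dose given. Nothing at hand bears on what lies behind this step.

The compounds shown leave open whether the step follows the tert-butoxycarbonyl group or the butyl chain itself, a question that a free amine or a carboxylic acid at the end of that chain would address. On these data alone, whether a longer chain moves the number further, or the step carries over to another dose, also remains open.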